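Chloro in place of methoxy on the arylpiperazine of the shared core

This account rests on a few compounds, and the source may have more. Where it says the series, first, only, none or still open, it means among the compounds named here.

Among the compounds with values here, compound 2 `COc1ccccc1N1CCN(Cn2nc(-c3ccc4c(c3)OCCO4)oc2=S)CC1` gives 15500 nM in a functional assay on HepG2 cells (Homo sapiens) for antiproliferative activity, read by MTT assay, with a stated time of 48 h (on this read-out lower numbers stand for stronger inhibition and higher numbers for weaker inhibition), one of only two numbers so far and within the scatter of compound 1 `S=c1oc(-c2ccc3c(c2)OCCO3)nn1CN1CCN(C(c2ccccc2)c2ccccc2)CC1`, which gives 9120 nM in this assay. Compound 3 `S=c1oc(-c2ccc3c(c2)OCCO3)nn1CN1CCN(c2ccccc2Cl)CC1` differs from compound 2 by chloro in place of methoxy on an aromatic carbon. Within the data shown here, no step between measured compounds bears on this exchange, so only the two numbers above guide the expectation. The expected step of a 1.3-fold lower number from compound 2 to compound 3 (0.11 log units; within the scatter) is small, nothing beyond the scatter in either direction. Compound 3 is estimated at 12000 nM in this assay, with a range from 5000 nM to 30000 nM.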

Compound 3, half-maximal inhibitory concentration: 11400 nM
Beside the measured number, compound 3's estimate is 1.1-fold (0.02 log units) above it; measured number inside the range.
By their numbers in this assay, from the lowest: compounds 1, 3 and 2 (each within the scatter of the next).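

In this assay, chloro in place of methoxy gives a 1.4-fold lower number from compound 2 to compound 3 (0.13 log units; within the scatter), the first step read at this position. On this aromatic carbon, ortho to a large group, 2-methoxyphenyl and 2-chlorophenyl are therefore not told apart by this read-out. Nothing measured here bears on the reason for this result.

Going by these compounds, whether an amine or a carboxylic acid on this aromatic carbon gives a step beyond the scatter remains open. Also open, on these data alone, is whether the same exchange reads alike elsewhere on this six-membered aromatic ring.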